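This account rests on a few compounds, and the source may have more. Where it says the series, first, only, none or still open, it means among the compounds named here.

Compound 3 `C=CC[C@H]1C[C@]2([C@@H](C)Cc3ccc(OC)c(C)c3)OCOC2=CC1=O` is measured in a functional assay on M14 cells (Homo sapiens) for antiproliferative activity, with a stated time of 72 h (a lower number here means a stronger inhibitor, a higher number a weaker inhibitor), and gives 410 nM. Of the two numbers recorded in this assay it is the higher one; its nearest neighbour is compound 1 `C=CC[C@H]1C[C@]2([C@H](C)Cc3ccc(OC)c(OC)c3)OCOC2=CC1=O`, which in this assay gives 300 nM, a gap that lies within the scatter. Compound 2 `C=CC[C@@H]1C[C@]2([C@H](C)Cc3ccc(OC)c(OC)c3)OCOC2=CC1=O` in this assay gives only a limit, > 4000 nM. The step of an at least 13-fold higher number from compound 1 to compound 2 (1.12 log units; beyond the scatter) is large, and it can be tied to the fact that compounds 1 and 2 differ only in the configuration as drawn, the outcome of which is recorded through (the limit of > 4000 nM in this assay, at which 1 of the 3 values shown sits).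

Compound 4 `C=CC[C@H]1C[C@]2([C@@H](C)Cc3ccc(OC)c(C(=O)NC)c3)OCOC2=CC1=O` is not yet measured. It differs from compound 3 in one place: methylcarbamoyl in place of methyl on an aromatic carbon. For the measured compounds named here, none of the measured steps touches the aromatic ring or any group on it; the only measured step is the change of configuration at the saturated ring carbon, so no measured step bears on the passage from compound 3 to compound 4. In the absence of any comparable measured step, the expected step is a 1.5-fold higher number from compound 3 to compound 4 (0.17 log units; within the scatter), that is, no change beyond the scatter, with wide uncertainty in either direction. For compound 4 the estimated value in this assay is 600 nM, expected to fall between 200 nM and 2500 nM.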

Compound 4, half-maximal inhibitory concentration: 1400 nM
For compound 4 the middle estimate is 2.3-fold (0.37 log units) below the measured one; the range from low to high includes it.
By their numbers in this assay, from the lowest: compounds 1 and 3 (each within the scatter of the next); then compound 4. At a limit, above all of these: compound 2.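

The series now holds a measured change on the aromatic ring: in this assay, methylcarbamoyl in place of methyl, on an aromatic carbon ortho to a methoxy group, gives a 3.4-fold higher number from compound 3 to compound 4 (0.53 log units; beyond the scatter). For the compounds shown here, until now the only measured step was a change of configuration at a saturated ring carbon, so this is the first sign that the group on this aromatic carbon itself moves the number, and that the move here is modest next to the one set by configuration, while compound 4 still returns a true value and not a limit. Nothing given here bears on why this exchange raises the number, so the step stands as an observation without an explanation.

Going by these compounds alone, the single pair cannot say whether the step belongs to the amide as such, to the amide hydrogen, or simply to a group of more heavy atoms at this place. As far as these compounds go, a primary carboxamide, a carboxylic acid, an amine or a longer alkyl chain on the same aromatic carbon would separate these readings, and whether the step holds at the opposite configuration also stays open.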